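Guanylhydrazone series: removing thiophene methyl groups

A few compounds are considered here, and "the series" means these few. Any claim that something is new, unique, unknown or untested is made for them only; others in the source may bear on it.

Measured so far:
Compound 1 `Cc1cc(-c2nc3sc(C)cn3c2/C=N/NC(=N)N)c(C)s1` gives 7410 nM in a functional assay on cells (Melanoma cell, Homo sapiens) for inhibition; a higher number here means a weaker inhibitor of growth, a lower number a stronger inhibitor of growth.
Compound 2 `Cc1cn2c(/C=N/Nc3ccccn3)c(-c3ccc(Cl)c([N+](=O)[O-])c3)nc2s1` gives 18200 nM in this assay.

Compound 1 holds the lower of the two numbers recorded so far; the number for compound 2 lies above it by a gap that is beyond the usual scatter. The two compounds differ in more than one place, so nothing can be said about which part of the structure carries that gap.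

Compound 3 `Cc1cn2c(/C=N/NC(=N)N)c(-c3ccsc3)nc2s1` is the next candidate. Its difference from compound 1 is thiophen-3-yl in place of 2,5-dimethylthiophen-3-yl on an aromatic carbon. Going by the values given here, no measured pair in this set isolates the effect of dropping the two methyl groups from the thiophene, so any expectation rests on compound 1 alone. With no guidance from a comparable step, the expected change from compound 1 to compound 3 is a 1.2-fold higher number from compound 1 to compound 3 (0.08 log units; within the scatter), which is taken as no step beyond the scatter, with a modest upward drift allowed. Compound 3 is therefore estimated at 9000 nM in this assay. The range for compound 3 is expected to run from 3000 nM to 30000 nM.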

Compound 3, concentration for 50% growth inhibition: 8130 nM
Compound 3: the middle estimate sits 1.1-fold (0.04 log units) above what was measured, and the stated range covers the measured number.
By their numbers in this assay, from the lowest: compounds 1 and 3 (each within the scatter of the next); then compound 2.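

Thiophen-3-yl in place of 2,5-dimethylthiophen-3-yl gives the first comparison in the series that isolates a single place, and in this assay it reads as a 1.1-fold higher number from compound 1 to compound 3 (0.04 log units; within the scatter). At this aromatic carbon, the two thiophene methyl groups can therefore be dropped together with no step beyond the scatter, so the growth-inhibition read-out does not separate the substituted thiophene from the plain one. No measured property is available to account for this result.

Because the two methyl groups leave together, the contribution of each one alone stays unresolved, and effects of opposite sign at the two thiophene carbons cannot be ruled out. On these data alone, whether a larger or different group here, such as an aminomethyl group or a carboxylic acid on the thiophene, would move the number beyond the scatter also remains open, as does the part of the structure that carries the gap to compound 2, which differs from compound 1 and compound 3 in more than one place.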